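Methoxy to hydroxy on the shared core

This account rests on a few compounds, and the source may have more. Where it says the series, first, only, none or still open, it means among the compounds named here.

Measured so far:
compound 1 `COc1cc(-c2nn(-c3cccc(NC(=O)c4ccc(Cl)c(C(F)(F)F)c4)c3)cc2-c2ccncc2)ccc1Cl` — > 32500 nM, a limit of the assay
compound 2 `COc1cc(-c2nn(-c3cccc(NC(=O)Nc4ccc(Cl)c(C(F)(F)F)c4)c3)cc2-c2ccncc2)ccc1Cl` — 15600 nM

Within the data shown here, in a functional assay on ACHN cells (Homo sapiens) for inhibition, read by sulforhodamine B assay, with a stated time of 48 h (a higher number here means a weaker inhibitor of growth, a lower number a stronger inhibitor of growth), compound 2 gives 15600 nM, the only number measured in the set. Compound 1 gives only a limit of the assay, > 32500 nM, in line with the limit of > 32500 nM in this assay, at which 1 of the 2 values shown sits. Among the measured compounds shown here, the single measured step, an at least 2.0-fold lower number from compound 1 to compound 2 (0.31 log units; beyond the scatter), concerns the amide-to-urea change and does not touch the oxygen substituent. Compound 3 `O=C(Nc1cccc(-n2cc(-c3ccncc3)c(-c3ccc(Cl)c(O)c3)n2)c1)Nc1ccc(Cl)c(C(F)(F)F)c1` differs from compound 2 by hydrogen in place of methyl on an oxygen on an aromatic ring. For the measured compounds named here, no measured step bears on this change, so no step beyond the scatter is expected. Compound 3 is therefore estimated at 15600 nM, with a range from 6000 nM to 40000 nM. This expectation corresponds to no change at the digits printed from compound 2 to compound 3 (within the scatter).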

Compound 3, concentration for total growth inhibition: > 32500 nM
Compound 3 ended at the assay's limit (the forecaster's own chance of this, stated with the estimate: 25%); middle value at least 2.0-fold (0.31 log units) from the limit.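

In this assay, hydrogen in place of methyl on an oxygen on an aromatic ring gives an at least 2.0-fold higher number from compound 2 to compound 3 (0.31 log units; beyond the scatter), so at this position on the urea series, methoxy and hydroxy are not interchangeable. Compound 3 gives > 32500 nM, which is a limit of the assay, so the size of the step has no upper bound. Most of the series now reads at that ceiling: the limit of > 32500 nM in this assay, at which 2 of the 3 values shown sit.

Open, as far as these compounds go, is how this position responds to other groups in place of methoxy, such as ethoxy or an amine. From the compounds shown here alone, whether any of these would give a lower number than the methoxy urea also remains open.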